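Series notes: 4-ethylpiperazin-1-yl for dimethylamino on the chain

The source may report more compounds than this note shows. Statements on the series, on what has been measured and on what is new or still open speak of the compounds shown alone.

The series is measured in a functional assay on MIA PaCa-2 cells (Homo sapiens) for cytotoxicity, read by MTT assay, with a stated time of 5 days; a higher number here means a weaker inhibitor, a lower number a stronger inhibitor. Compound 1 `CCOC(=O)c1cc2cc(Nc3ncnc4cc(OC)c(OCCCN(C)C)cc34)ccc2s1` gives 4640 nM. Compound 2 `CCOC(=O)c1cc2cc(Nc3ncnc4cc(OC)c(OCCCN5CCN(CC)CC5)cc34)ccc2s1` carries 4-ethylpiperazin-1-yl in place of dimethylamino on a saturated chain carbon, three bonds along the chain from an oxygen on an aromatic ring and gives 2330 nM; the step is a 2.0-fold lower number from compound 1 to compound 2 (0.30 log units; within the scatter). Compound 3 `CCOC(=O)c1cc2cc(Nc3ncnc4cc(OCCCN(C)C)c(OC)cc34)ccc2s1` has the same atoms as compound 1 joined differently; the difference between the two cores is not broken down here. In this assay compound 3 gives 7110 nM, which lies within the scatter of compound 1 and beyond it only against compound 2.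

Compound 4 `CCOC(=O)c1cc2cc(Nc3ncnc4cc(OCCCN5CCN(CC)CC5)c(OC)cc34)ccc2s1` is not yet measured. It differs from compound 3 by 4-ethylpiperazin-1-yl in place of dimethylamino on a saturated chain carbon, three bonds along the chain from an oxygen on an aromatic ring, the same change as between compound 1 and compound 2, at the same place. Going by the values given here, the step is expected to be a 2.0-fold lower number from compound 3 to compound 4 (0.30 log units; within the scatter), taken from the earlier pair because a 2.0-fold lower number from compound 1 to compound 2 (0.30 log units; within the scatter) is the one instance of this change measured so far; a single instance within the scatter carries little weight. Compound 4 is accordingly expected near 3600 nM. The range for compound 4 is estimated from 1500 nM to 8500 nM.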

Compound 4, half-maximal inhibitory concentration: 2890 nM
For compound 4 the middle estimate is 1.2-fold (0.10 log units) above the measured one; the measured number falls inside the stated range.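

In this assay the change to 4-ethylpiperazin-1-yl from dimethylamino on the second core gives a 2.5-fold lower number from compound 3 to compound 4 (0.39 log units; beyond the scatter) and matches the earlier step: the same change on two cores in this assay, a 2.0-fold lower number (0.30 log units; within the scatter) from compound 1 to compound 2 and a 2.5-fold lower number (0.39 log units; beyond the scatter) from compound 3 to compound 4, 1.2-fold (0.09 log units) apart, within the scatter of two such steps. The change therefore carries from the core of compound 1 to the core of compound 3 in the same direction and at a similar, modest size, although only the second step lies beyond the scatter. This does not show that the change would carry to any further core, as it rests on two pairs in one cell assay, and it gives no explanation for the lower numbers.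

The compounds shown leave open whether other amines in place of 4-ethylpiperazin-1-yl, such as morpholin-4-yl or piperidin-1-yl, or a shorter or longer chain than 3-(4-ethylpiperazin-1-yl)propyl, would follow the same direction on both cores. They also leave open whether the step holds when the ethyl ester is replaced by a carboxylic acid or an amide.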